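The compounds below may be only part of what the source reports. "The series", "measured", "known", "first", "only" and "open" are said of these compounds alone.

Compound 1 `COc1ccc(-c2cc3ccccc3nc2/C=C/C(=O)c2ccco2)cc1` — 640 nM
Compound 2 `COc1ccc(-c2cc3ccccc3nc2/C=C/C(=O)c2ccsc2)cc1` — 660 nM

Two ketone variants of the shared core have been run in a functional assay on SK-BR-3 cells (Homo sapiens) for antiproliferative activity, read by XTT assay, with a stated time of 72 h (on this read-out lower numbers stand for stronger inhibition and higher numbers for weaker inhibition), so far. Compound 2 sits alongside compound 1 with no separation of note: the step of a 1.0-fold higher number from compound 1 to compound 2 (0.01 log units; within the scatter) exchanged one five-membered aromatic ring with one hetero atom for another on the carbonyl carbon and left the number essentially where it was.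

Compound 3 `COc1ccc(-c2cc3ccccc3nc2/C=C/C(=O)c2ccc[nH]2)cc1` continues this exchange: 1H-pyrrol-2-yl in place of thiophen-3-yl on a carbonyl carbon. Among the measured compounds shown here, the only measured step that bears on it is a 1.0-fold higher number from compound 1 to compound 2 (0.01 log units; within the scatter), a ring swap of the same kind and size at the same position, which was flat. For the measured compounds named here, the new ring differs in bringing a hydrogen-bond donor and no acceptor; no measured step speaks to that, so nothing beyond the scatter is anticipated in this assay, in either direction. Compound 3 is expected at 700 nM, ranging from 350 nM to 1500 nM. The expected step is a 1.1-fold higher number from compound 2 to compound 3 (0.03 log units; within the scatter).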

Compound 3, half-maximal inhibitory concentration: > 10000 nM
Compound 3 gave a limit, no number (the forecaster's own chance of this, stated with the estimate: 3%); at least 14-fold (1.15 log units) between middle value and limit.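

In this assay compound 3 gives a limit and not a number: the limit of > 10000 nM in this assay, at which 1 of the 3 values shown sits.

The ring on the carbonyl carbon is therefore not interchangeable, although the earlier exchange was flat (a 1.0-fold higher number from compound 1 to compound 2 (0.01 log units; within the scatter)): 1H-pyrrol-2-yl in place of thiophen-3-yl gives an at least 15-fold higher number from compound 2 to compound 3 (1.18 log units; beyond the scatter), and 1H-pyrrol-2-yl in place of furan-2-yl gives an at least 15-fold higher number from compound 1 to compound 3 (1.19 log units; beyond the scatter). The exchange from thiophen-3-yl brings in a hydrogen-bond donor and removes a hydrogen-bond acceptor, but the compounds shown cannot separate either change from the identity of the ring.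

Going by these compounds, whether the loss follows the ring's hydrogen remains open, and a 1-methyl-1H-pyrrol-2-yl ring on the carbonyl carbon would bear directly on that question. On these data alone, the actual value of compound 3 also remains unknown, so the full size of both large steps is undefined.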